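This account rests on a few compounds, and the source may have more. Where it says the series, first, only, none or still open, it means among the compounds named here.

Compound 1 `Oc1cccc(-c2cc(-c3ccccc3F)cc(-c3ccccc3O)n2)c1` and compound 3 `Oc1ccc(-c2cc(-c3ccc(OC(F)(F)F)cc3)cc(-c3cccc(O)c3)n2)cc1` were both tested in a functional assay on T47D cells (Homo sapiens) for inhibition; on this read-out higher numbers stand for weaker inhibition and lower numbers for stronger inhibition. In this assay compound 1 gives 24200 nM, while compound 3 gives 18900 nM; the gap between these two numbers lies within the usual scatter, so neither can be called the more potent. The difference between the core of compound 1 and the core of compound 3 is not broken down here.

Compound 2 `Oc1ccc(-c2cc(-c3ccccc3F)cc(-c3ccccc3O)n2)cc1` is the partner of compound 1 that carries the change (4-hydroxyphenyl in place of 3-hydroxyphenyl on an aromatic carbon). For compound 2 the assay reports only a limit, > 50000 nM, and not a number. The step of an at least 2.0-fold higher number from compound 1 to compound 2 (0.31 log units; beyond the scatter) therefore rests on that limit, as does the observation (the limit of > 50000 nM in this assay, at which 1 of the 3 values shown sits).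

Compound 4 `Oc1ccc(-c2cc(-c3ccc(OC(F)(F)F)cc3)cc(-c3ccc(O)cc3)n2)cc1` stands to compound 3 as compound 2 stands to compound 1, through the change (4-hydroxyphenyl in place of 3-hydroxyphenyl on an aromatic carbon). The surroundings are not identical: in compound 1 the site is meta to a 2-fluorophenyl group and meta to a 2-hydroxyphenyl group, whereas in compound 3 it is meta to a 4-hydroxyphenyl group and meta to a large group, so this is the same kind of change rather than the same change. The expectation for compound 4 is a step of about a 2.4-fold higher number from compound 3 to compound 4 (0.38 log units; beyond the scatter) in this assay, set beside an at least 2.0-fold higher number from compound 1 to compound 2 (0.31 log units; beyond the scatter), resting on the weaker inhibition seen for compound 2 after the same kind of change. Compound 4 is thus estimated at 45000 nM, with a plausible range from 20000 nM to 100000 nM, and a fair chance that only a limit is reported.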

Compound 4, half-maximal inhibitory concentration: 5150 nM
For compound 4 the middle estimate is 8.7-fold (0.94 log units) above the measured one; measured number outside the range, below it.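

In this assay, replacing 3-hydroxyphenyl with 4-hydroxyphenyl on the core of compound 3 gives a 3.7-fold lower number from compound 3 to compound 4 (0.56 log units; beyond the scatter), which means stronger inhibition on this core and a step opposite in direction to the one seen on the core of compound 1: the same change on two cores in this assay, an at least 2.0-fold higher number (0.31 log units; beyond the scatter) from compound 1 to compound 2 and a 3.7-fold lower number (0.56 log units; beyond the scatter) from compound 3 to compound 4, at least 7.5-fold (0.87 log units) apart, beyond the scatter of two such steps

The change therefore does not carry over as a fixed step from one core to the other, and the step seen on one of these two cores gives no safe forecast for the other. Which of the differences between the cores goes with the reversal is not shown, and the size of the earlier step stays open, as compound 2 carries only a limit: the limit of > 50000 nM in this assay, at which 1 of the 4 values shown sits.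

The compounds shown leave open whether the direction of the step follows the 2-fluorophenyl group, the trifluoromethoxy group or the other hydroxyphenyl group, each of which differs between the two cores. They also leave open how an amine, a carboxylic acid or a methoxy group in place of the hydroxyl of the 4-hydroxyphenyl group would read in this assay.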